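A few compounds are considered here, and "the series" means these few. Any claim that something is new, unique, unknown or untested is made for them only; others in the source may bear on it.

Three compounds have been measured:
compound 1, `CCCc1nc(-c2ccccc2)c(CNCCCN2CCN(c3ccc(F)cc3)CC2)o1`, which gives 62.5% in an assay on HEK293 cells for inhibition of Voltage-dependent T-type calcium channel subunit alpha-1G (Homo sapiens), read by fluorescence, tested at 10 uM; on this read-out higher numbers stand for more inhibition at the one concentration tested (going by the name of the read-out) and lower numbers for less inhibition;
compound 2, `CCCc1nc(-c2ccccc2)c(CNCCCN2CCN(c3cccc(C)c3C)CC2)o1`, which gives 55.2% in this assay;
compound 3, `CCCc1nc(-c2ccccc2)c(CNCCCN2CCN(c3ccccc3OC)CC2)o1`, which gives 41% in this assay.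

All three share one core and differ only in the group on an amine nitrogen in a ring. Compound 3 stands lowest of the three: the step of a number 21.5 percentage points lower from compound 1 to compound 3 (beyond the scatter) and the step of a number 14.2 percentage points lower from compound 2 to compound 3 (beyond the scatter) both lie beyond the scatter, while a number 7.3 percentage points lower from compound 1 to compound 2 (within the scatter) does not.

Compound 4, `CCCc1nc(-c2ccccc2)c(CNCCCN2CCN(c3ccc(C)c(C)c3)CC2)o1`, has not yet been measured. Its change from compound 3 is 3,4-dimethylphenyl in place of 2-methoxyphenyl on an amine nitrogen in a ring. The step that bears most directly on this is a number 14.2 percentage points lower from compound 2 to compound 3 (beyond the scatter), where 2,3-dimethylphenyl gave way to 2-methoxyphenyl and the number fell; compound 4 reverses that exchange, though with the two methyl groups arranged as 3,4-dimethylphenyl rather than 2,3-dimethylphenyl. The step of a number 21.5 percentage points lower from compound 1 to compound 3 (beyond the scatter) points the same way. A modest rise is therefore expected in this assay, back toward the numbers of compound 1 and compound 2. The expected step is a number 11 percentage points higher from compound 3 to compound 4 (beyond the scatter). Compound 4 is estimated at 52%, within a range from 35% to 68%.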

Compound 4, a percentage reported as inhibition, at one concentration (the size of the read-out at that concentration, not a potency): 54.6%
Beside the measured number, compound 4's estimate is 2.6 percentage points below it; the range from low to high includes it.
By their numbers in this assay, from the lowest: compound 3; then compounds 4, 2 and 1 (each within the scatter of the next).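

The exchange of 2-methoxyphenyl for 3,4-dimethylphenyl on an amine nitrogen in a ring gives a number 13.6 percentage points higher from compound 3 to compound 4 (beyond the scatter) in this assay, so a second dimethylphenyl group now stands apart from 2-methoxyphenyl. Moving the two methyl groups around the ring, from 2,3-dimethylphenyl to 3,4-dimethylphenyl, gives a number 0.6 percentage points lower from compound 2 to compound 4 (within the scatter), so the read-out resolves no effect of that rearrangement among these compounds. Going by these compounds alone, the comparison with 4-fluorophenyl gives a number 7.9 percentage points lower from compound 1 to compound 4 (within the scatter), which leaves compound 3 as the only one of the four set apart from all the others, and also the only one whose group at this position holds an oxygen.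

Nothing measured here explains why the 2-methoxyphenyl compound stands apart. From the compounds shown here alone, it stays open whether the oxygen itself or its place on the ring goes with the lower number, and a phenyl ring carrying a hydroxyl group, or a pyridine ring on this nitrogen, would test new ground; each number also comes from a single concentration and so says nothing of potency.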